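Same Ring Swap on a Second Core: Compound 4

The source may report more compounds than this note shows. Statements on the series, on what has been measured and on what is new or still open speak of the compounds shown alone.

Of the compounds shown here, three have been tested so far. Compound 1 `COc1cc2ncnc(N3CCc4ccccc43)c2cc1NC(=O)/C=C/CN1CCN(C)CC1` carries a 4-methylpiperazin-1-yl on a saturated chain carbon bound to a double-bonded chain carbon, and in a functional assay on PC-3 cells (Homo sapiens) for antiproliferative activity, read by MTT assay, with a stated time of 72 h (a lower number here means a stronger inhibitor, a higher number a weaker inhibitor), compound 1 gives 9180 nM. Compound 2 `COc1cc2ncnc(N3CCc4ccccc43)c2cc1NC(=O)/C=C/CN1CCC(CO)CC1` differs from compound 1 by 4-(hydroxymethyl)piperidin-1-yl in place of 4-methylpiperazin-1-yl on a saturated chain carbon bound to a double-bonded chain carbon; in this assay compound 2 gives 2650 nM, a step of a 3.5-fold lower number from compound 1 to compound 2 (0.54 log units; beyond the scatter). Compound 3 `CN1CCN(C/C=C/C(=O)Nc2cc3c(N4CCc5ccccc54)ncnc3cc2O[C@@H]2CCOC2)CC1` differs from compound 1 in its core by oxolan-3-yl in place of methyl on an oxygen on an aromatic ring; in this assay compound 3 gives 4210 nM, a step of a 2.2-fold lower number from compound 1 to compound 3 (0.34 log units; beyond the scatter). The values of compound 2 and compound 3 lie within the scatter of each other.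

Compound 4 `O=C(/C=C/CN1CCC(CO)CC1)Nc1cc2c(N3CCc4ccccc43)ncnc2cc1O[C@@H]1CCOC1` has not yet been measured. It differs from compound 3 by 4-(hydroxymethyl)piperidin-1-yl in place of 4-methylpiperazin-1-yl on a saturated chain carbon bound to a double-bonded chain carbon. Going by the values given here, this is the same change as the one made from compound 1 to compound 2, at the same place, so that earlier step is the natural guide. Compound 4 is expected to give about 1200 nM in this assay, with a likely range from 500 nM to 3000 nM, which would mean an expected step of a 3.5-fold lower number from compound 3 to compound 4 (0.55 log units; beyond the scatter). Among the compounds with values here, this expectation rests on the earlier step of a 3.5-fold lower number from compound 1 to compound 2 (0.54 log units; beyond the scatter) being modest but beyond the scatter, and on compound 3 starting from 4210 nM; only one earlier example of the change exists, so the range is kept wide.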

Compound 4, half-maximal inhibitory concentration: 3310 nM
Estimate against measurement, compound 4: 2.8-fold (0.44 log units) below; measured number outside the range, above it.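

In this assay, the swap from 4-methylpiperazin-1-yl to 4-(hydroxymethyl)piperidin-1-yl does not keep its size when carried from the core of compound 1 to the core of compound 3, where it gives a 1.3-fold lower number from compound 3 to compound 4 (0.10 log units; within the scatter) and so cannot be told apart from no change at all: the same change on two cores in this assay, a 3.5-fold lower number (0.54 log units; beyond the scatter) from compound 1 to compound 2 and a 1.3-fold lower number (0.10 log units; within the scatter) from compound 3 to compound 4, 2.7-fold (0.44 log units) apart, beyond the scatter of two such steps. Seen from the other side, oxolan-3-yl in place of methyl on an oxygen on an aromatic ring gives a 1.2-fold higher number from compound 2 to compound 4 (0.10 log units; within the scatter) when the 4-(hydroxymethyl)piperidin-1-yl group is already present, so this change also depends on what stands at the other place: the same change on two cores in this assay, a 2.2-fold lower number (0.34 log units; beyond the scatter) from compound 1 to compound 3 and a 1.2-fold higher number (0.10 log units; within the scatter) from compound 2 to compound 4, 2.7-fold (0.44 log units) apart, beyond the scatter of two such steps. The two changes therefore do not simply add up in these four compounds, but the data do not show why, and a single pair of cores cannot tell how the swap would behave on any further core.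

The compounds shown leave open how other amines on the same chain carbon, such as morpholin-4-yl or dimethylamino, would behave on these two cores. They also leave open whether another group on the oxygen, such as ethyl or a longer chain ending in an amine, would shrink the step as oxolan-3-yl does.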